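Notes on the step from compound 3 to compound 4

The source may hold more compounds than are shown below. What is called first, only, known or untested is meant among the compounds shown, and "the series" means these compounds.

In a functional assay on MCF7 cells (Homo sapiens) for antiproliferative activity, read by sulforhodamine B assay, with a stated time of 48 h (on this read-out lower numbers stand for stronger inhibition and higher numbers for weaker inhibition), compound 1 (`CN1CCN(c2ccc(S(=O)(=O)Oc3c(Cl)cc(Cl)cc3Cl)cc2)C1=O`) gives 2900 nM as a measured number. Compound 2 (`CN1CCN(c2ccc(S(=O)(=O)Oc3ccc(Cl)cc3)cc2)C1=O`) gives > 100000 nM and this is a limit, not a number. Compound 3 (`CCCN1CCN(c2ccc(S(=O)(=O)Oc3c(Cl)cc(Cl)cc3Cl)cc2)C1=O`) gives > 100000 nM and this too is a limit. Compound 3 therefore has no measured potency and sits at the limit of > 100000 nM in this assay, at which 2 of the 3 values shown sit, together with one other compound.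

Compound 4 (`CCCN1CCN(c2ccc(S(=O)(=O)Oc3ccc(F)cc3)cc2)C1=O`) keeps the chain of compound 3 and carries 4-fluorophenyl in place of 2,4,6-trichlorophenyl on an oxygen. Among the compounds with values here, no measured step covers this exchange directly. Within the data shown here, the one measured step that bears on compound 4 is an at least 34-fold higher number from compound 1 to compound 3 (1.53 log units; beyond the scatter) and it is large, beyond the scatter; compound 4 retains the chain of that step. Compound 2 also lacks the 2,4,6-trichlorophenyl group and stands at the limit of > 100000 nM in the same way.

Compound 4 thus combines the two features found in the compounds at the limit, so no step beyond the scatter is expected in this assay. The expected change is a number no higher from compound 3 to compound 4 (the limit leaves the size open) in this estimate. Compound 4 is estimated at 100000 nM with an expected range from 30000 nM to 300000 nM and will most likely be reported only as a limit.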

Compound 4, half-maximal inhibitory concentration: 33000 nM
Estimate against measurement, compound 4: 3.0-fold (0.48 log units) above, within the range that was stated.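

In this assay, 4-fluorophenyl in place of 2,4,6-trichlorophenyl on an oxygen gives an at least 3.0-fold lower number from compound 3 to compound 4 (0.48 log units; beyond the scatter), the first step at this position among the compounds shown. With the chain of compound 3 kept, a measured number therefore does not depend on 2,4,6-trichlorophenyl, and compound 4 gives 33000 nM. This chain thus does not by itself put a compound at the limit, despite an at least 34-fold higher number from compound 1 to compound 3 (1.53 log units; beyond the scatter). Compound 3 carries a limit and not a number, so the full size of the step stays open: the limit of > 100000 nM in this assay, at which 2 of the 4 values shown sit.

The compounds shown leave open how 4-fluorophenyl behaves on the shorter chain of compound 1, and whether the step follows from the entry of the fluorine or from the loss of the chlorines, a question that an unsubstituted phenyl on the same oxygen would address. Also open, as far as these compounds go, is how far the chain can vary with 4-fluorophenyl in place, for example with a butyl chain or with a hydrogen on that ring nitrogen.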